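Phenyl in Place of Methyl: What Compound 3 May Show

A few compounds are considered here, and "the series" means these few. Any claim that something is new, unique, unknown or untested is made for them only; others in the source may bear on it.

Compound 1 `CC(C)(C)NCC(O)COc1ncns1`: 76.5% in a functional assay on the whole organism (artery, strain mongrel) for inhibition, with Canis familiaris (Canis lupus familiaris) as the target, with a stated time of 20 min, at a dose of 14.58 mg/kg by the intravenous route; on this read-out higher numbers stand for a stronger effect at the one dose given and lower numbers for a weaker effect
Compound 2 `Cc1nsc(OCC(O)CNC(C)(C)C)n1`: 85.3% in this assay

Of these two numbers, compound 2 stands at the top on paper, but the step of a number 8.8 percentage points higher from compound 1 to compound 2 (within the scatter) lies within the scatter, so the two compounds cannot be told apart by this read-out. Compound 3 `CC(C)(C)NCC(O)COc1nc(-c2ccccc2)ns1` differs from compound 2 by a single change, (phenyl in place of methyl on an aromatic carbon). For the measured compounds named here, the only measured step that bears on it is the one from compound 1 to compound 2, also a change on an aromatic carbon, and it was small. Since no larger change at that place has been measured, the step of a number 5.3 percentage points lower from compound 2 to compound 3 (within the scatter) is expected to stay within the scatter, with no clear direction. Compound 3 is thus estimated at 80%, within a range from 55% to 95%.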

Compound 3, a percentage reported as inhibition, in the whole organism at one dose (the size of the read-out at that dose, not a potency): 100%
Estimate against measurement, compound 3: 20 percentage points below; measured number outside the range, above it.
By their numbers in this assay, from the lowest: compounds 1 and 2 (each within the scatter of the next); then compound 3.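

Phenyl in place of methyl gives a number 14.7 percentage points higher from compound 2 to compound 3 (beyond the scatter) and phenyl in place of hydrogen gives a number 23.5 percentage points higher from compound 1 to compound 3 (beyond the scatter) in this assay and so this aromatic carbon, where hydrogen and methyl could not be told apart, does respond to the group it carries. Phenyl is the first group at this place to give a step beyond the scatter, which sets compound 3 clearly above both compound 1 and compound 2 on this read-out. No evidence on the cause of this step is given.

On these data alone, what a cyclohexyl ring, a pyridyl ring or a butyl chain would give at this carbon stays open, and with it whether an aromatic ring is needed for the step at all. As far as these compounds go, the read-out shows the size of the effect at one dose, so whether the stronger effect of compound 3 would hold at other doses also remains open.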